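Fluoro to chloro on the pendant phenyl ring of compound 3

The compounds below may be only part of what the source reports. "The series", "measured", "known", "first", "only" and "open" are said of these compounds alone.

Of the compounds shown here, three that share one core have been measured in an assay on isolated protein for inhibition of Amine oxidase [flavin-containing] B (Homo sapiens), read by fluorescence, with a stated time of 1 h; a lower number here means a stronger inhibitor, a higher number a weaker inhibitor. The unsubstituted parent, compound 1 `c1ccc(-c2nc3ccc(N4CCCCC4)nc3o2)cc1`, gives 1370 nM. Adding fluoro on an aromatic carbon of the pendant ring gives compound 2 `Fc1ccccc1-c1nc2ccc(N3CCCCC3)nc2o1`, which gives 665 nM, and compound 3 `Fc1cccc(-c2nc3ccc(N4CCCCC4)nc3o2)c1`, which gives 272 nM. The steps were a 2.1-fold lower number from compound 1 to compound 2 (0.31 log units; beyond the scatter) and a 5.0-fold lower number from compound 1 to compound 3 (0.70 log units; beyond the scatter), and moving the fluoro from one position to the other was a 2.4-fold lower number from compound 2 to compound 3 (0.39 log units; beyond the scatter). Compound 3 therefore stands lowest of the three numbers, with compound 2 nearest and compound 1 furthest.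

Compound 4 `Clc1cccc(-c2nc3ccc(N4CCCCC4)nc3o2)c1` has not yet been measured. It differs from compound 3 by chloro in place of fluoro on an aromatic carbon, on an aromatic carbon of a six-membered aromatic ring of carbon only, meta to a large group. Among the measured compounds shown here, none of the measured steps exchanges one halogen for another; they only show that a halogen at this place is tolerated and that placement matters. A small step in either direction, possibly none beyond the scatter, is therefore expected in this assay, as a 1.1-fold lower number from compound 3 to compound 4 (0.04 log units; within the scatter). Compound 4 is estimated at 250 nM, within a range from 100 nM to 650 nM.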

Compound 4, half-maximal inhibitory concentration: 335 nM
Estimate against measurement, compound 4: 1.3-fold (0.13 log units) below; the range from low to high includes it.
By their numbers in this assay, from the lowest: compounds 3, 4 and 2 (each within the scatter of the next, the first and the last beyond it); then compound 1.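

In this assay, exchanging one halogen for the other at this place gives a 1.2-fold higher number from compound 3 to compound 4 (0.09 log units; within the scatter), so the 3-chlorophenyl and 3-fluorophenyl compounds cannot be told apart, and the place accepts chloro as well as fluoro. Among the compounds shown here, the gain over the unsubstituted parent also holds with the larger halogen, as chloro in place of hydrogen gives a 4.1-fold lower number from compound 1 to compound 4 (0.61 log units; beyond the scatter) and so extends to chloro what the earlier compounds showed only for fluoro; against the 2-fluorophenyl compound the change is a 2.0-fold lower number from compound 2 to compound 4 (0.30 log units; within the scatter) and, unlike the fluoro shift between those two positions, does not clear the scatter. No measurement accompanies these numbers to account for the two halogens reading alike.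

The compounds shown leave open whether bromo, methyl, methoxy or trifluoromethyl at this same place would hold the number where the two halogens hold it, or would move it. They also leave open whether chloro at the place the fluoro occupies in compound 2 would follow the fluoro there.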